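The source may hold more compounds than are shown below. What is called first, only, known or untested is meant among the compounds shown, and "the series" means these compounds.

Of the compounds shown here, two have been measured in an assay for inhibition of NADPH oxidase 1 (Homo sapiens), read by chemiluminescence; a lower number here means a stronger inhibitor, a higher number a weaker inhibitor. Compound 1, with the structure `CN1C(=S)N(C2CCCCC2)C(=O)/C1=C/c1cccc(O)c1O`, gives 7390 nM in this assay. Compound 2, with the structure `CCc1ccc(N2C(=O)/C(=C/c3ccc(O)cc3O)N(C)C2=S)cc1`, gives 8400 nM in this assay. Of these two numbers, compound 2 shows the larger one, yet its gap to compound 1 falls within the usual scatter of repeated measurements, so the two cannot be told apart on this evidence.

Compound 3, with the structure `CCc1ccc(N2C(=O)/C(=C/c3cccc(O)c3O)N(C)C2=S)cc1`, has not yet been measured. It differs from compound 2 in one place: 2,3-dihydroxyphenyl in place of 2,4-dihydroxyphenyl on a double-bonded chain carbon bound to a double-bonded ring carbon. The rest of the molecule is kept as in compound 2.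

Among the compounds with values here, no step between two measured compounds that differ in a single place is available, so the size of this change cannot be read directly from a matched pair. Because compound 1 gives 7390 nM while carrying the same 2,3-dihydroxyphenyl group, the step from compound 2 to compound 3 is expected to stay within the scatter, a 1.2-fold lower number from compound 2 to compound 3 (0.08 log units; within the scatter). Compound 3 is therefore expected to give 7000 nM in this assay, with a range from 3000 nM to 16000 nM.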

Compound 3, inhibition constant: 27900 nM
Estimate against measurement, compound 3: 4.0-fold (0.60 log units) below; the whole stated range lies below it.
By their numbers in this assay, from the lowest: compounds 1 and 2 (each within the scatter of the next); then compound 3.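

In this assay, putting 2,3-dihydroxyphenyl in place of 2,4-dihydroxyphenyl on a double-bonded chain carbon bound to a double-bonded ring carbon gives a 3.3-fold higher number from compound 2 to compound 3 (0.52 log units; beyond the scatter), so this place responds to how the two hydroxyl groups are arranged, even though the atoms and the donor and acceptor counts of the group stay the same. With 2,3-dihydroxyphenyl held constant, 4-ethylphenyl in place of cyclohexyl on an amide-type nitrogen in a ring gives a 3.8-fold higher number from compound 1 to compound 3 (0.58 log units; beyond the scatter), showing that this second place also affects the result and that the closeness of the values of compounds 1 and 2, which differ in both places, does not mean that either place is without effect. Nothing available accounts for either step.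

The compounds shown leave open whether the two steps add up or depend on each other, a question that the pairing of cyclohexyl with 2,4-dihydroxyphenyl would address. They also leave open how a single hydroxyl group, a methoxy group in place of either hydroxyl, or a chain longer than ethyl on the phenyl ring would fare in this assay.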